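Methylating a ring amine: a small change in tolerated concentration

The source may report more compounds than this note shows. Statements on the series, on what has been measured and on what is new or still open speak of the compounds shown alone.

Measured compounds:
compound 1, `CC1(C)[C@H]2CC[C@]1(C)[C@H](OC(=O)CCN1CCNCC1)C2`: 12600 nM
compound 2, `CCCCN(CCCC)CCC(=O)O[C@@H]1C[C@@H]2CC[C@@]1(C)C2(C)C`: 41800 nM

In an ADME assay on MDCK cells (Canis lupus familiaris) for cytotoxicity, read by MTT assay, with a stated time of 48 h (a lower number here means that less compound is tolerated, a higher number that more compound is tolerated), compound 1 gives 12600 nM, the lowest of the two numbers shown. Compound 2 sits higher, and its gap from compound 1 is beyond the scatter, so compound 1 is the less tolerated of the two.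

Compound 3, `CN1CCN(CCC(=O)O[C@@H]2C[C@@H]3CC[C@@]2(C)C3(C)C)CC1`, has not yet been measured. It differs from compound 1 in one place: methyl in place of hydrogen on an amine nitrogen in a ring. Within the data shown here, no step between measured compounds that differ in one place is available to guide the estimate. A change this small, at an amine nitrogen in a ring, gives no clear reason to expect a shift in this assay beyond the scatter in either direction.

Compound 3 is therefore estimated at 15000 nM, with a range from 7000 nM to 32000 nM. The step of a 1.2-fold higher number from compound 1 to compound 3 (0.08 log units; within the scatter) is expected to lie within the usual scatter.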

Compound 3, half-maximal cytotoxic concentration: 48100 nM
Beside the measured number, compound 3's estimate is 3.2-fold (0.51 log units) below it, and the stated range ends below it.
By their numbers in this assay, from the lowest: compound 1; then compounds 2 and 3 (each within the scatter of the next).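

In this assay the change from piperazin-1-yl to 4-methylpiperazin-1-yl gives a 3.8-fold higher number from compound 1 to compound 3 (0.58 log units; beyond the scatter) and so counts as a modest step, though one beyond the scatter. This shows that the amine nitrogen in the ring is not a place where a small change goes unnoticed: one methyl in place of one hydrogen is enough to move the tolerated concentration upward. The data at hand offer no explanation for this shift.

From the compounds shown here alone, what remains open is whether this rise belongs to methyl alone or would also follow other groups on the same nitrogen, such as an ethyl group, a longer chain or an acetyl group. A single step also cannot show whether the same change would act alike on a different core.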